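Dropping the benzyl ring: from compound 3 to compound 4

The source may hold more compounds than are shown below. What is called first, only, known or untested is meant among the compounds shown, and "the series" means these compounds.

Measured so far in a functional assay on FM3A cells (Mus musculus) for cytotoxicity, read by cell counting, with a stated time of 2 days; a lower number here means a stronger inhibitor, a higher number a weaker inhibitor:
Compound 1, `Nc1ccc(/C=C2\SC(=O)N(Cc3ccc(C(F)(F)F)cc3)C2=O)cc1`, gives 134000 nM.
Compound 2, `Nc1ccc(/C=C2\SC(=O)N(Cc3cccc(F)c3)C2=O)cc1`, gives 121000 nM.
Compound 3, `Nc1ccc(/C=C2\SC(=O)N(Cc3ccc(Cl)cc3)C2=O)cc1`, gives 60000 nM.

All three share the same core and differ only in the ring hanging from the nitrogen. Compound 3 is set apart from compound 1 by a 2.2-fold lower number from compound 1 to compound 3 (0.35 log units; beyond the scatter), a shift large enough to count, whereas its gap to compound 2, a 2.0-fold lower number from compound 2 to compound 3 (0.30 log units; within the scatter), falls inside the usual scatter, so compounds 2 and 3 cannot be told apart on these numbers.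

Compound 4, `CN1C(=O)S/C(=C\c2ccc(N)cc2)C1=O`, takes a different kind of step: hydrogen in place of 4-chlorophenyl on a saturated chain carbon bound to an amide-type nitrogen in a ring. The measured steps only swapped one substituent for another on that ring, and neither of them moved the numbers far. For the measured compounds named here, no step removes the ring altogether, so there is no direct precedent; the change is larger than anything measured, and the direction is open. Since even small swaps on the ring shifted this assay by about a 2.2-fold lower number from compound 1 to compound 3 (0.35 log units; beyond the scatter), compound 4 is expected to differ from compound 3 by at least that much, with the estimate placed toward a weaker inhibitor, a 2.5-fold higher number from compound 3 to compound 4 (0.40 log units; beyond the scatter). Compound 4 is therefore estimated at 150000 nM, within a wide range from 40000 nM to 600000 nM.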

Compound 4, half-maximal inhibitory concentration: 107000 nM
For compound 4 the middle estimate is 1.4-fold (0.15 log units) above the measured one, within the range that was stated.
By their numbers in this assay, from the lowest: compounds 3, 4, 2 and 1 (each within the scatter of the next, the first and the last beyond it).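

In this assay, the whole 4-chlorophenyl ring, with its 7 heavy atoms, gives way to hydrogen in a 1.8-fold higher number from compound 3 to compound 4 (0.25 log units; within the scatter), and the same exchange for 3-fluorophenyl gives a 1.1-fold lower number from compound 2 to compound 4 (0.05 log units; within the scatter). The earlier compounds shown here only showed one ring substituent swapped for another, whereas these two steps show that, on a saturated chain carbon bound to an amide-type nitrogen in a ring, losing the aromatic ring altogether leaves compound 4 indistinguishable from compound 2 and compound 3 on these numbers, so for these two pairs the ring makes no readable difference to cell killing in this assay. Nothing in the available data offers an explanation for this flat result.

From the compounds shown here alone, it remains open whether a group of a different kind at this position, such as a longer chain ending in an amine or a carboxylic acid, would move the number beyond the scatter. For the compounds shown here, it also remains open whether changes elsewhere on the shared core would have a larger effect than anything seen at this position so far.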